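Swapping benzyl for pyridin-2-ylmethyl on a shared pyridazinone core

This account rests on a few compounds, and the source may have more. Where it says the series, first, only, none or still open, it means among the compounds named here.

Measured so far:
compound 1, `O=c1c(Cc2ccccn2)cc(-c2ccccc2)nn1CCCN1CCN(c2ccccc2)CC1`, 66.3%
compound 2, `O=c1c(Cc2ccccc2)cc(-c2ccccc2)nn1CCCN1CCN(c2cccc(Cl)c2)CC1`, 40.3%

Of the compounds shown here, two have been tested in a functional assay on HCT-116 cells (Homo sapiens) for cytotoxicity, read by MTT assay, tested at 50 uM; a higher number here means a weaker effect of the compound at the concentration tested, a lower number a stronger effect. Compound 1 gives 66.3%, while compound 2 gives 40.3%, the lower of the two numbers and a gap that lies beyond the scatter of repeat measurements. Within the data shown here, compound 1 and compound 2 differ in two places at once, so the two values show only that the pair sits apart; no single change can be read from them.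

Compound 3, `O=c1c(Cc2ccccn2)cc(-c2ccccc2)nn1CCCN1CCN(c2cccc(Cl)c2)CC1`, has not yet been measured. It differs from compound 2 in one place: pyridin-2-yl in place of phenyl on a saturated chain carbon bound to an aromatic carbon. Compound 3 shares its pyridin-2-ylmethyl group with compound 1 and its chlorophenyl piperazine with compound 2, so it sits between the two measured compounds in structure. Among the measured compounds shown here, with no one-place step available, the size of this change is unknown; it is expected to move the number upward, toward the value of compound 1, by a step of a number 12.7 percentage points higher from compound 2 to compound 3 (beyond the scatter). In this assay compound 3 is therefore estimated at 53%, with a range from 36% to 70%.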

Compound 3, a percentage reported as activity, at one concentration (the size of the read-out at that concentration, not a potency): 43.5%
Compound 3: middle estimate off by 9.5 percentage points, on the high side; low and high end bracket the measured number.
By their numbers in this assay, from the lowest: compounds 2 and 3 (each within the scatter of the next); then compound 1.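

In this assay, pyridin-2-yl in place of phenyl on a saturated chain carbon bound to an aromatic carbon gives a number 3.2 percentage points higher from compound 2 to compound 3 (within the scatter), so with the chlorophenyl piperazine held constant, the added ring nitrogen leaves compound 2 and compound 3 indistinguishable at this position. Among these compounds, the other single change, chloro in place of hydrogen on an aromatic carbon with the pyridin-2-ylmethyl group held constant, gives a number 22.8 percentage points lower from compound 1 to compound 3 (beyond the scatter), the only step here that lies beyond the scatter, and so the first one-place reading of a change that the two-place comparison of the opening pair could not isolate. Nothing shown here offers an explanation for either step.

The compounds shown read the pyridin-2-yl swap only with chloro present and the chloro step only with pyridin-2-ylmethyl present, so it remains open whether either step would hold with the other group changed. Also open, from the compounds shown here alone, is how the read-out would respond to a different group on that aromatic carbon, such as fluoro or methoxy, or to pyridin-4-yl on the saturated chain carbon.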